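Halogen swap on the core of a weakly active azido nucleoside

The source may report more compounds than this note shows. Statements on the series, on what has been measured and on what is new or still open speak of the compounds shown alone.

Compound 1 `[N-]=[N+]=N[C@H]1C(n2cnc3c(N)nc(Cl)nc32)O[C@H](CO)[C@@H]1O`: > 120000 nM
Compound 2 `Nc1nc(Cl)nc2c1ncn2C1O[C@H](CO)[C@H](O)[C@H]1N`: 80000 nM

In a functional assay on HEp-2 cells (Homo sapiens) (a lower number here means a stronger inhibitor, a higher number a weaker inhibitor), compound 1 sits at the assay limit, > 120000 nM. Compound 2 gives 80000 nM. The step of an at least 1.5-fold lower number from compound 1 to compound 2 (0.17 log units; that floor lies within the scatter) is only a floor because of the limit of > 120000 nM in this assay, at which 1 of the 2 values shown sits. Compound 3 `[N-]=[N+]=N[C@H]1C(n2cnc3c(N)nc(F)nc32)O[C@H](CO)[C@@H]1O` differs from compound 1 by fluoro in place of chloro on an aromatic carbon. For the measured compounds named here, no measured step exchanges one halogen for another on the aromatic carbon, so the single measured step, which concerns the saturated ring position, does not bear on this change. Compound 3 is therefore expected to move no further than the scatter, a step that the limit leaves unreadable from compound 1 to compound 3. The estimate for compound 3 is 150000 nM, from 60000 nM to 400000 nM, most likely reported again only as a limit.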

Compound 3, half-maximal inhibitory concentration: 29000 nM
Compound 3: the middle estimate sits 5.2-fold (0.71 log units) above what was measured, outside the stated range (below it).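

In this assay, the aromatic carbon between two ring nitrogen atoms responds to the halogen: fluoro in place of chloro gives an at least 4.1-fold lower number from compound 1 to compound 3 (0.61 log units; beyond the scatter). For the compounds shown here, the earlier change on the saturated ring carbon gave only a floor within the scatter, so this is the first step that is clearly readable. As far as these compounds go, its true size remains unknown because it too is only a floor: the limit of > 120000 nM in this assay, at which 1 of the 3 values shown sits.

From the compounds shown here alone, whether bromo or methoxy on this aromatic carbon would lower the number further remains open. So does whether fluoro would have the same effect on the core of compound 2.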